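The source may hold more compounds than are shown below. What is called first, only, known or untested is meant among the compounds shown, and "the series" means these compounds.

Three compounds sharing one core have been measured in a functional assay on MGC-803 cells (Homo sapiens) for inhibition, read by sulforhodamine B assay; a higher number here means a weaker inhibitor, a lower number a stronger inhibitor:
compound 1 `Cc1ccc(NC2=CC(=O)c3c(nc4n3[C@H]3OC[C@@H](O)[C@H]3OC4)C2=O)cc1` gives 1550 nM
compound 2 `CCOc1ccc(NC2=CC(=O)c3c(nc4n3[C@H]3OC[C@@H](O)[C@H]3OC4)C2=O)cc1` gives 2090 nM
compound 3 `CCOc1ccccc1NC1=CC(=O)c2c(nc3n2[C@H]2OC[C@@H](O)[C@H]2OC3)C1=O` gives 2830 nM

Compound 1 stands at the lowest of the three numbers, yet the steps of a 1.3-fold higher number from compound 1 to compound 2 (0.13 log units; within the scatter) and a 1.8-fold higher number from compound 1 to compound 3 (0.26 log units; within the scatter) both lie within the scatter, as does a 1.4-fold higher number from compound 2 to compound 3 (0.13 log units; within the scatter), so the three compounds sit on a par. Compound 4 `CCCN(CCC)C1=CC(=O)c2c(nc3n2[C@H]2OC[C@@H](O)[C@H]2OC3)C1=O` differs from compound 1 in one place: dipropylamino in place of (4-methylphenyl)amino on a double-bonded ring carbon. Within the data shown here, none of the measured steps bears on this change. Each of them swaps one aromatic amine for another, whereas here the aromatic ring leaves altogether and a dipropylamino group enters. There is thus no measured guide to the size or direction of the step, and the estimate is held close to the measured values with a wide range. Compound 4 is expected to give 3000 nM, estimated between 800 nM and 12000 nM. This estimate means an expected step of a 1.9-fold higher number from compound 1 to compound 4 (0.29 log units; within the scatter).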

Compound 4, half-maximal inhibitory concentration: > 16000 nM
Compound 4: no number, only a limit (the forecaster's own chance of this, stated with the estimate: 10%); middle value at least 5.3-fold (0.72 log units) from the limit.
By their numbers in this assay, from the lowest: compounds 1, 2 and 3 (each within the scatter of the next). At a limit, above all of these: compound 4.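

In this assay, dipropylamino in place of (4-methylphenyl)amino gives an at least 10-fold higher number from compound 1 to compound 4 (1.01 log units; beyond the scatter), so compound 4 is a clearly weaker inhibitor. Compound 4 has a limit of the assay rather than a number: the limit of > 16000 nM in this assay, at which 1 of the 4 values shown sits. The aromatic amines of compounds 1, 2 and 3 sit within the scatter of one another, but this position does not tolerate every amine.

The change removes the aromatic ring and the amine hydrogen together, so the compounds shown cannot separate the two. Propylamino, which keeps the hydrogen without the ring, and benzylamino remain open.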